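Removing the 3,5-difluorophenyl group from compound 3

The source may hold more compounds than are shown below. What is called first, only, known or untested is meant among the compounds shown, and "the series" means these compounds.

In a functional assay on MCF7 cells (Homo sapiens) for antiproliferative activity, read by MTT assay, with a stated time of 72 h (on this read-out lower numbers stand for stronger inhibition and higher numbers for weaker inhibition), compound 1 `O=C1O[C@H]([C@@H](O)Cn2cc(-c3ccc(Br)cc3)nn2)C(OCc2ccccc2)=C1OCc1ccccc1` gives 5620 nM and compound 2 `CCCCc1cn(C[C@H](O)[C@H]2OC(=O)C(OCc3ccccc3)=C2OCc2ccccc2)nn1` gives 7910 nM with a step of a 1.4-fold higher number from compound 1 to compound 2 (0.15 log units; within the scatter) between them. Compound 3 `O=C1O[C@H]([C@@H](O)Cn2cc(-c3cc(F)cc(F)c3)nn2)C(OCc2ccccc2)=C1OCc1ccccc1` is the weakest of the three at 27700 nM after steps of a 4.9-fold higher number from compound 1 to compound 3 (0.69 log units; beyond the scatter) and a 3.5-fold higher number from compound 2 to compound 3 (0.54 log units; beyond the scatter) in turn. Compound 4 `O=C1O[C@H]([C@@H](O)Cn2ccnn2)C(OCc2ccccc2)=C1OCc1ccccc1` differs from compound 3 by hydrogen in place of 3,5-difluorophenyl on an aromatic carbon with hydrogen in place of 3,5-difluorophenyl on an aromatic carbon. The measured steps swap one group at this carbon for another, and none removes it, so they offer only modest sizes as a guide. For compound 4 the expected change is a 1.1-fold higher number from compound 3 to compound 4 (0.03 log units; within the scatter) and so none beyond the scatter. Compound 4 is estimated at 30000 nM within an expected range from 11000 nM to 90000 nM for now.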

Compound 4, half-maximal inhibitory concentration: > 100000 nM
Compound 4 was reported as a limit; the forecaster's own chance of this, stated with the estimate: 25%; at least 3.3-fold (0.52 log units) between middle value and limit.
By their numbers in this assay, from the lowest: compounds 1 and 2 (each within the scatter of the next); then compound 3. At a limit, above all of these: compound 4.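

Compound 4 stands only as a limit: the limit of > 100000 nM in this assay, at which 1 of the 4 values shown sits. Hydrogen on this aromatic carbon gives an at least 3.6-fold higher number from compound 3 to compound 4 (0.55 log units; beyond the scatter), an at least 12-fold higher number from compound 2 to compound 4 (1.10 log units; beyond the scatter) and an at least 17-fold higher number from compound 1 to compound 4 (1.25 log units; beyond the scatter). The earlier steps shown here only swapped one group for another, whereas these show that 3,5-difluorophenyl, butyl and 4-bromophenyl each give a lower number than hydrogen at this carbon.

The compounds shown leave open whether a group as small as methyl, or a butyl chain ending in an amine or a carboxylic acid, would hold the number near those of compound 1 and compound 2. As far as these compounds go, the full size of the three steps also stays open.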